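A 3-ethoxyphenyl in place of the ethenyl-linked ring

This account rests on a few compounds, and the source may have more. Where it says the series, first, only, none or still open, it means among the compounds named here.

Among the compounds with values here, compound 2 `COC(=O)/C=C/c1cccc(N(Cc2ccc(/C=C/c3ccc(F)cc3)cc2)C(=O)C(C)C)c1` gives 120 nM in an assay on isolated protein with Bile acid receptor (Homo sapiens) as the target (a lower number here means that less compound is needed, a higher number that more compound is needed for the effect), the lowest of the two numbers so far; compound 1 `COC(=O)/C=C/c1cccc(N(Cc2ccc(/C=C/c3cccc(C(F)(F)F)c3)cc2)C(=O)C(C)C)c1` gives 267 nM. Within the data shown here, the single measured step, a 2.2-fold lower number from compound 1 to compound 2 (0.35 log units; beyond the scatter), came from exchanging 3-(trifluoromethyl)phenyl for 4-fluorophenyl and does not bear directly on the present change. Compound 3 `CCOc1cccc(-c2ccc(CN(C(=O)C(C)C)c3cccc(/C=C/C(=O)OC)c3)cc2)c1` differs from compound 2 by 3-ethoxyphenyl in place of 2-(4-fluorophenyl)ethenyl on an aromatic carbon. Without a comparable measured step, no change beyond the scatter is expected, and compound 3 is estimated at 200 nM, between 70 nM and 600 nM. For compound 3 this expectation corresponds to a 1.7-fold higher number from compound 2 to compound 3 (0.22 log units; within the scatter).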

Compound 3, half-maximal effective concentration: 173 nM
Estimate against measurement, compound 3: 1.2-fold (0.06 log units) above; measured number inside the range.
By their numbers in this assay, from the lowest: compounds 2, 3 and 1 (each within the scatter of the next, the first and the last beyond it).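

At this aromatic carbon, para to a large group, 3-ethoxyphenyl can stand in place of 2-(4-fluorophenyl)ethenyl, with a 1.4-fold higher number from compound 2 to compound 3 (0.16 log units; within the scatter) in this assay. Set against the 2-(3-(trifluoromethyl)phenyl)ethenyl group, the same kind of exchange gives a 1.5-fold lower number from compound 1 to compound 3 (0.19 log units; within the scatter), so the ethenyl link is not required here for a number in this range. Nothing measured here gives a reason for this result. Still open, on these data alone, is how a methoxy group in place of the ethoxy chain would read, and how an amine or a carboxylic acid on this ring would read.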